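The source may hold more compounds than are shown below. What is called first, only, known or untested is meant among the compounds shown, and "the series" means these compounds.

Compounds measured so far in an assay on HEK293 cells for displacement of a labelled ligand from NPC1-like intracellular cholesterol transporter 1 (Homo sapiens); a lower number here means a stronger inhibitor, a higher number a weaker inhibitor:
Compound 1 `CC1CCCN(C(=O)CN2CN(c3ccccc3)C3(CCN(C(=O)c4ccc(C(C)(C)C)cc4)CC3)C2=O)C1` gives 12000 nM in this assay.
Compound 2 `CCOC(=O)C1CCN(C(=O)CN2CN(c3ccccc3)C3(CCN(C(=O)c4ccc(C(C)(C)C)cc4)CC3)C2=O)CC1` gives 3100 nM in this assay.

Among the measured compounds shown here, compound 2 holds the lower of the two numbers, its nearest neighbour being compound 1, and the single measured step of a 3.9-fold lower number from compound 1 to compound 2 (0.59 log units; beyond the scatter) is a modest one. Compound 3 `CCc1nn(CC)c(C2CCN(C(=O)CN3CN(c4ccccc4)C4(CCN(C(=O)c5ccc(C(C)(C)C)cc5)CC4)C3=O)CC2)c1CC` carries a further change at the same saturated ring carbon: 1,3,4-triethyl-1H-pyrazol-5-yl in place of ethoxycarbonyl on a saturated ring carbon. For the measured compounds named here, only the step from compound 1 to compound 2 bears on this change, and it shows that a substituent on that ring carbon can shift the number by a modest amount. Going by the values given here, no measured step speaks to an aromatic ring at that position, so the direction is uncertain. Compound 3 is therefore expected to show a small step, a 1.6-fold lower number from compound 2 to compound 3 (0.19 log units; within the scatter), and its estimated value in this assay is 2000 nM, within a range from 500 nM to 8000 nM.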

Compound 3, half-maximal inhibitory concentration: 4600 nM
For compound 3 the middle estimate is 2.3-fold (0.36 log units) below the measured one; measured number inside the range.
By their numbers in this assay, from the lowest: compounds 2 and 3 (each within the scatter of the next); then compound 1.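

In this assay the exchange at this saturated ring carbon (a 1.5-fold higher number from compound 2 to compound 3 (0.17 log units; within the scatter)) stays within the scatter, so the result cannot separate the two groups. The change is nonetheless a large one in structure: 1,3,4-triethyl-1H-pyrazol-5-yl has 11 heavy atoms and a five-membered aromatic ring, whereas ethoxycarbonyl has 5 heavy atoms and no ring, and the earlier compounds had not shown an aromatic ring at this position. No measurement available here offers an explanation for this outcome.

The compounds shown leave open whether a carboxylic acid or a primary amine on this ring carbon would move the number beyond the scatter. They also leave open what the three ethyl groups contribute, since an unsubstituted pyrazole or a phenyl ring does not appear among them.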